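Extending a bromophenyl ether chain on a stilbene

The compounds below may be only part of what the source reports. "The series", "measured", "known", "first", "only" and "open" are said of these compounds alone.

Measured compounds:
compound 1 `C/C=C/COc1cc(/C=C\c2cc(OC)c(OC)c(OC)c2)ccc1OC`, 161000 nM
compound 2 `COc1ccc(/C=C\c2cc(OC)c(OC)c(OC)c2)cc1OCc1ccc(Br)cc1`, 108000 nM
compound 3 `COCOc1cccc(/C=C/CCCOc2cc(/C=C\c3cc(OC)c(OC)c(OC)c3)ccc2OC)c1`, 59000 nM

In a functional assay on HT-29 cells (Homo sapiens) for inhibition, read by MTT assay, with a stated time of 3 days (on this read-out lower numbers stand for stronger inhibition and higher numbers for weaker inhibition), compound 2 gives 108000 nM, the second highest of the three numbers, yet its gap to compound 1 and its gap to compound 3 are both within the scatter, so the three compounds cannot be told apart on these data. Compound 4 `COc1ccc(/C=C\c2cc(OC)c(OC)c(OC)c2)cc1OCCC/C=C/c1ccc(Br)cc1` has not been measured. It differs from compound 2 in one place: a group of 11 heavy atoms (10 carbon, 1 bromine; one six-membered aromatic ring of carbon only) in place of a group of 7 heavy atoms (6 carbon, 1 bromine; one six-membered aromatic ring of carbon only), on a saturated chain carbon bound to an oxygen on an aromatic ring.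

For the measured compounds named here, only one measured step bears on this change. The step of a 1.5-fold lower number from compound 1 to compound 2 (0.17 log units; within the scatter) also replaced the group on a saturated chain carbon bound to an oxygen on an aromatic ring and moved the number within the scatter. Compound 3, which carries a longer chain with a double bond outside aromatic rings at the same place, gives 59000 nM, again within the scatter of compound 2. He therefore expects the step of a 1.4-fold lower number from compound 2 to compound 4 (0.16 log units; within the scatter) to stay within the scatter. For compound 4 he estimates 75000 nM, with a range from 25000 nM to 200000 nM.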

Compound 4, half-maximal inhibitory concentration: 11000 nM
Compound 4: the middle estimate sits 6.8-fold (0.83 log units) above what was measured; the measured number lies below the stated range.
By their numbers in this assay, from the lowest: compound 4; then compounds 3, 2 and 1 (each within the scatter of the next, the first and the last beyond it).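

In this assay, the group on a saturated chain carbon bound to an oxygen on an aromatic ring proves able to move the number beyond the scatter, as a 9.8-fold lower number from compound 2 to compound 4 (0.99 log units; beyond the scatter) and a 15-fold lower number from compound 1 to compound 4 (1.17 log units; beyond the scatter) show, whereas the earlier step at this place stayed within it. Neither the 4-bromophenyl of compound 2 nor the longer chain with a double bond of compound 3 gave this alone, and a 5.4-fold lower number from compound 3 to compound 4 (0.73 log units; beyond the scatter) shows that, on that chain, the 4-bromophenyl in place of 3-(methoxymethoxy)phenyl also lies beyond the scatter. Nothing measured here explains the effect of combining them.

The compounds shown leave open whether the double bond or the added chain length carries the step, and whether a fully saturated chain of the same length would do the same. They also leave open whether an amine or a carboxylic acid in place of the bromine would keep it.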